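This account rests on a few compounds, and the source may have more. Where it says the series, first, only, none or still open, it means among the compounds named here.

Measured so far:

Compound 1, `CC1CCN(c2c(S(=O)(=O)c3cc(F)cc(F)c3)cnc3ccc(Cl)cc23)CC1`, gives 93%.
Compound 2, `CC1CCN(c2c(S(=O)(=O)c3ccccc3)cnc3ccc(Cl)cc23)CC1`, gives 59%.
Compound 3, `CC1CCN(c2c(S(=O)(=O)c3ccccc3)cnc3ccccc23)CC1`, gives 89.2%.

These three share one core and were tested in an assay on isolated protein for displacement of a labelled ligand from metabotropic glutamate receptor 5 (Homo sapiens), with a stated time of 60 min, tested at 1 uM; a lower number here means less inhibition, a higher number more inhibition at the concentration tested (going by the name of the read-out). Compound 2 has the lowest of the three numbers: it sits below compound 3 by the step of a number 30.2 percentage points higher from compound 2 to compound 3 (beyond the scatter) and below compound 1 by the step of a number 34 percentage points lower from compound 1 to compound 2 (beyond the scatter), both beyond the usual scatter.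

The new compound 4, `CC1CCN(c2c(S(=O)(=O)c3ccc(C#N)cc3)cnc3ccc(Cl)cc23)CC1`, differs from compound 2 in one place: cyano in place of hydrogen on an aromatic carbon. The change sits on the same phenyl ring that was altered between compound 1 and compound 2, where fluorines on that ring went with a large drop when removed, a number 34 percentage points lower from compound 1 to compound 2 (beyond the scatter). The step from compound 2 to compound 3 changes a different place, the chloro on the core, and says nothing direct about this ring. Putting a group back onto the phenyl is therefore expected to move this assay upward, by a step of moderate to large size, a number 16 percentage points higher from compound 2 to compound 4 (beyond the scatter).

Compound 4 is thus estimated at 75%, with a likely range from 50% to 95%.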

Compound 4, a percentage reported as inhibition, at one concentration (the size of the read-out at that concentration, not a potency): 31%
The estimate for compound 4 lay 44 percentage points above the measured number, and the stated range ends above it.
By their numbers in this assay, from the lowest: compound 4; then compound 2; then compounds 3 and 1 (each within the scatter of the next).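

On the phenyl ring attached to the sulfonyl sulfur, adding a group does not by itself raise the number in this assay: the change to 4-cyanophenyl gives a number 28 percentage points lower from compound 2 to compound 4 (beyond the scatter). The comparison with the 3,5-difluorophenyl ring gives a number 62 percentage points lower from compound 1 to compound 4 (beyond the scatter), so the two substituted rings fall on opposite sides of the plain phenyl, and the identity of the group on this ring matters, not merely the presence of one. The data shown offer no explanation for why the cyano and fluoro rings part ways.

As far as these compounds go, whether the fall is particular to cyano remains open, as a methoxy group or an amine in place of the cyano could show whether other groups at this place go the same way. It is also unknown whether the cyano would have a similar effect on the core without the chloro.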